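Amide series: oral inhibition notes, compound 1 to compound 4

The source may report more compounds than this note shows. Statements on the series, on what has been measured and on what is new or still open speak of the compounds shown alone.

Measured compounds:
- compound 1 `COc1ccc(-c2ccc(OC)c3oc(C(=O)Nc4ccc(Cn5ccnc5)cc4)cc23)cc1` — in a functional assay on the whole organism for inhibition, with Mus musculus as the target, at a dose of 10 mg/kg by the oral route (on this read-out higher numbers stand for more inhibition at the one dose given (going by the name of the read-out) and lower numbers for less inhibition), compound 1 gives 54%
- compound 2 `COc1ccc(-c2ccccc2)c2cc(C(=O)Nc3c(Cl)cncc3Cl)oc12` — compound 2 gives 74%
- compound 3 `COc1ccc(-c2ccccc2)c2cc(C(=O)NN3CCOCC3)oc12` — compound 3 gives 78%

Compound 1 stands lowest of the three, with compound 2 and compound 3 each above it beyond the scatter. Going by the values given here, the single measured step, a number 4 percentage points higher from compound 2 to compound 3 (within the scatter), concerns the amide-type nitrogen and not the position changed here.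

Compound 4 `COC(=O)c1ccc(OC)c2oc(C(=O)Nc3ccc(Cn4ccnc4)cc3)cc12` differs from compound 1 in one place: methoxycarbonyl in place of 4-methoxyphenyl on an aromatic carbon. Among the compounds with values here, no measured pair covers a change of this kind on the core, so the numbers give no direction for it. The step of a number 2 percentage points lower from compound 1 to compound 4 (within the scatter) is expected to be none beyond the scatter. Compound 4 is estimated at 52%, within 30% to 72%.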

Compound 4, a percentage reported as inhibition, in the whole organism at one dose (the size of the read-out at that dose, not a potency): 0%
For compound 4 the middle estimate is 52 percentage points above the measured one, and the stated range ends above it.
By their numbers in this assay, from the lowest: compound 4; then compound 1; then compounds 2 and 3 (each within the scatter of the next).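

Replacing 4-methoxyphenyl with methoxycarbonyl on this aromatic carbon of the shared core gives a number 54 percentage points lower from compound 1 to compound 4 (beyond the scatter) in this assay. This position therefore does not accept every group, and one change here can remove the whole read-out at the single oral dose, a far larger step than the only earlier one, which lay on the amide-type nitrogen. Nothing available bears on the reason for this drop.

As far as these compounds go, it remains open whether the drop follows from the departure of the aromatic ring or the arrival of methoxycarbonyl. A benzyl group or a carboxylic acid on the same carbon could help separate the two.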